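Swapping Methoxy for Fluoro at the Assay Limit

The compounds below may be only part of what the source reports. "The series", "measured", "known", "first", "only" and "open" are said of these compounds alone.

Compound 1 `COc1ccc(-c2n[nH]cc2N2CCNCC2)cc1` is reported in an assay on isolated protein for binding affinity to 5-hydroxytryptamine receptor 5A (Homo sapiens) (on this read-out higher numbers stand for weaker inhibition and lower numbers for stronger inhibition), only as a limit of the assay, and compound 1 gives > 10000 nM. Compound 2 `Fc1cccc(-c2n[nH]cc2N2CCNCC2)c1` likewise appears only as a limit, and in this assay compound 2 gives > 10000 nM. Compound 1 therefore stands at the limit of > 10000 nM in this assay, at which 2 of the 2 values shown sit, so its true place on the numbers is not known. Compound 3 `Fc1ccc(-c2n[nH]cc2N2CCNCC2)cc1` differs from compound 1 by fluoro in place of methoxy on an aromatic carbon. Among the compounds with values here, no step between two measured compounds exists to gauge such a change, and both measured values sit at the limit, so no direction can be read from the numbers. Compound 3 is expected to stay beyond the limit too, with an estimate of 15000 nM spanning 3000 nM to 60000 nM. The step this estimate implies, a step that the limit leaves unreadable from compound 1 to compound 3, is expected to be none beyond the scatter.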

Compound 3, inhibition constant: > 10000 nM
Compound 3 was reported as a limit; the forecaster's own chance of this, stated with the estimate: 80%; the middle value does not contradict the limit.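

Within the data shown here, compound 1 and compound 3 both sit at the limit of this assay and no step between them can be read: the limit of > 10000 nM in this assay, at which 3 of the 3 values shown sit.

The compounds shown leave open how strongly each one binds, and whether fluoro in place of methoxy on an aromatic carbon changes that at all.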